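Changing the aryl group on a triazole: three limits

This account rests on a few compounds, and the source may have more. Where it says the series, first, only, none or still open, it means among the compounds named here.

Compound 1, `Cc1cccc(-n2nncc2CN2C(=O)C3(C(C#N)=C(N)Oc4c(N)cc5nc6ccccc6nc5c43)c3ccccc32)c1`, in an ADME assay on L02 cells (Homo sapiens) for antiproliferative activity, read by MTT assay, with a stated time of 48 h (on this read-out higher numbers stand for weaker inhibition and lower numbers for stronger inhibition), gives > 50000 nM, which is a limit of the assay.
Compound 2, `N#CC1=C(N)Oc2c(N)cc3nc4ccccc4nc3c2C12C(=O)N(Cc1cnnn1-c1ccc(F)cc1)c1ccccc12`, in this assay gives > 50000 nM, again a limit.
Compound 3, `Cc1ccc(-n2nncc2CN2C(=O)C3(C(C#N)=C(N)Oc4c(N)cc5nc6ccccc6nc5c43)c3ccccc32)cc1C`, in this assay gives > 50000 nM, also a limit.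

Compound 3 therefore stands at the limit itself, alongside the other two compounds, as summed up by the limit of > 50000 nM in this assay, at which 3 of the 3 values shown sit. Compound 4, `N#CC1=C(N)Oc2c(N)cc3nc4ccccc4nc3c2C12C(=O)N(Cc1cnnn1-c1cc(Cl)ccc1Cl)c1ccccc12`, differs from compound 3 in one place: 2,5-dichlorophenyl in place of 3,4-dimethylphenyl on an aromatic nitrogen. Among the compounds with values here, the steps that bear on this change all concern the aryl group on the same aromatic nitrogen: a step that the two limits leave unreadable from compound 1 to compound 2, a step that the two limits leave unreadable from compound 1 to compound 3 and a step that the two limits leave unreadable from compound 2 to compound 3. None of them can be read as a size, so they give no direction for the new aryl group, only the observation that every aryl group tried so far left the measurement at the limit. The step that the limit leaves unreadable from compound 3 to compound 4 is accordingly expected to stay within the scatter. Compound 4 is estimated at 80000 nM, with a range from 30000 nM to 200000 nM, and most probably it will again be reported only as a limit.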

Compound 4, half-maximal inhibitory concentration: > 50000 nM
Compound 4: a limit, no number; the forecaster's own chance of this, stated with the estimate: 85%; the middle value does not contradict the limit.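

Within the data shown here, compound 4 also gives only a limit, so no step linking it to compound 1, compound 2 or compound 3 can be read as a size: the limit of > 50000 nM in this assay, at which 4 of the 4 values shown sit. In this assay the four compounds leave open how strongly each one acts and whether changing the aryl group matters at all.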